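The compounds below may be only part of what the source reports. "The series", "measured", "known", "first", "only" and "open" are said of these compounds alone.

Compound 1 `COc1cc(C2CC(c3ccccc3)=NN2C(C)=O)ccc1O`: 5780 nM
Compound 2 `CC(=O)N1N=C(c2ccco2)CC1c1ccc(Cl)cc1`: 38900 nM
Compound 3 `O=CCN1N=C(c2ccc3ccccc3c2)CC1c1ccccc1`: 10000 nM

These values come from a functional assay on IMR-32 cells (Homo sapiens) for cytotoxicity, read by sulforhodamine B assay, with a stated time of 48 h; on this read-out higher numbers stand for weaker inhibition and lower numbers for stronger inhibition. Compound 3, at 10000 nM, lies within the scatter of compound 1, while compound 2, at 38900 nM, gives a higher number, beyond the scatter from compound 3. Compound 4 `O=CCN1N=C(c2ccc3ccccc3c2)CC1c1ccccc1[N+](=O)[O-]` has nitro in place of hydrogen on an aromatic carbon, ortho to a large group, a change from phenyl to 2-nitrophenyl: nitro in place of hydrogen on an aromatic carbon. Among the compounds with values here, no measured pair shows what such a change does in this assay, so no step beyond the scatter is expected. The estimated step is a 1.3-fold lower number from compound 3 to compound 4 (0.10 log units; within the scatter). For compound 4, the expected value is 8000 nM, with an estimated range of 2500 nM to 25000 nM.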

Compound 4, half-maximal inhibitory concentration: 3360 nM
For compound 4 the middle estimate is 2.4-fold (0.38 log units) above the measured one; the measured number falls inside the stated range.
By their numbers in this assay, from the lowest: compounds 4, 1 and 3 (each within the scatter of the next, the first and the last beyond it); then compound 2.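

In this assay nitro in place of hydrogen on an aromatic carbon, ortho to a large group, gives a 3.0-fold lower number from compound 3 to compound 4 (0.47 log units; beyond the scatter) and this step lies beyond the scatter. It is the first pair shown that differs in one place, and it shows that the number responds to a change at this position, in this one case of phenyl to 2-nitrophenyl. Nothing available explains the step. Going by these compounds, whether an amine or a carboxylic acid at the same position would move the number in the same way remains open.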